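Swapping a Hydroxy for Methoxymethyl on the Amine Chain

A few compounds are considered here, and "the series" means these few. Any claim that something is new, unique, unknown or untested is made for them only; others in the source may bear on it.

Of the compounds shown here, two built on a shared core have been tested so far. Compound 1 `COc1cc(/C=C/C(=O)/C=C(/C=C/c2ccc(O)c(OC)c2)NCCO)ccc1O` and compound 2 `O=C(/C=C(/C=C/c1ccc(O)cc1)NCCO)/C=C/c1ccc(O)cc1` both carry an amine with a short side chain. In a functional assay on Caco-2 cells (Homo sapiens) for activation, read by fluorescence, tested at 1 uM (a lower number here means a stronger effect, a higher number a weaker effect of the compound at the concentration tested), compound 1 gives 103%, and compound 2 gives 98.1%. Of the two numbers, that of compound 1 sits at the top, but compound 2 falls within the usual scatter of it, so the two readings cannot be told apart, and both lie close to the level at which a compound has no effect at all.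

Compound 3 `COCCCNC(=C\C(=O)/C=C/c1ccc(O)c(OC)c1)/C=C/c1ccc(O)c(OC)c1` has not yet been measured. It differs from compound 1 in a single place: methoxymethyl in place of hydroxy on a saturated chain carbon, two bonds along the chain from an amine nitrogen. For the measured compounds named here, no step between measured compounds is available to show what such a change does here. Because compound 1 gives 103%, close to no effect, the expected step is a number 3 percentage points lower from compound 1 to compound 3 (within the scatter), that is, none beyond the scatter. Compound 3 is therefore expected to give 100% in this assay, with a plausible range from 85% to 115%.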

Compound 3, a percentage reported as activity, at one concentration (the size of the read-out at that concentration, not a potency): 97.9%
For compound 3 the middle estimate is 2.1 percentage points above the measured one; low and high end bracket the measured number.
By their numbers in this assay, from the lowest: compounds 3, 2 and 1 (each within the scatter of the next).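

For the compounds shown here, the first measured step at this position is small: putting methoxymethyl in place of hydroxy on a saturated chain carbon, two bonds along the chain from an amine nitrogen, gives a number 5.1 percentage points lower from compound 1 to compound 3 (within the scatter) in this assay and so cannot be told apart from repeated measurement of the same compound. The side chain can therefore lose its hydrogen-bond donor and gain heavy atoms, going from (2-hydroxyethyl)amino to (3-methoxypropyl)amino, without a detectable shift in this read-out, but the swap does not bring the compound away from the no-effect level either. No measured information here explains this outcome.

Since compound 1 already sits close to no effect, this flat result cannot show whether the chain matters when a compound is active in this assay at all. It also leaves open whether a quite different end to the chain, such as a carboxylic acid or a primary amine, or a longer chain, would move the number beyond the scatter.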